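Adding a Chloro Group to Compound 3

A few compounds are considered here, and "the series" means these few. Any claim that something is new, unique, unknown or untested is made for them only; others in the source may bear on it.

Of the compounds shown here, three have so far been tested in a functional assay on OVCAR-8 cells (Homo sapiens) for cytotoxicity, read by sulforhodamine B assay, with a stated time of 48 h; on this read-out higher numbers stand for weaker inhibition of growth and lower numbers for stronger inhibition of growth. Compound 1 `ClCc1ccccc1Cn1cnc2c(Cl)nc(Cl)nc21` gives 1230 nM in this assay. Compound 2 `ClCc1ccccc1Cn1cnc2c(Cl)ncnc21` carries one chloro group fewer on its core, and in this assay compound 2 gives 2240 nM. Compound 3 `ClCc1cccc(Cn2cnc3ncnc(Cl)c32)c1` is built from the same atoms as compound 2, joined differently; the difference between the two cores is not broken down here. In this assay compound 3 gives 3090 nM, the highest of the three numbers, though its gap to compound 2 lies within the scatter of repeated measurements, while its gap to compound 1 lies beyond it.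

The change from compound 2 to compound 1 is chloro in place of hydrogen on an aromatic carbon, and it produced a 1.8-fold lower number from compound 2 to compound 1 (0.26 log units; within the scatter), a step that stays within the usual scatter. Compound 4 `ClCc1cccc(Cn2cnc3nc(Cl)nc(Cl)c32)c1` has not yet been measured. It differs from compound 3 by chloro in place of hydrogen on an aromatic carbon, which is the same change, made on the other core, since the surroundings of the new chloro group read identically in both cases.

Within the data shown here, the only guide is that single measured step, so the expectation is modest. Compound 4 is expected to give about 1700 nM in this assay, with a plausible range from 800 nM to 3500 nM. For compound 4 the estimated step is a 1.8-fold lower number from compound 3 to compound 4 (0.26 log units; within the scatter), because the same change gave a 1.8-fold lower number from compound 2 to compound 1 (0.26 log units; within the scatter).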

Compound 4, concentration for 50% growth inhibition: 9330 nM
Beside the measured number, compound 4's estimate is 5.5-fold (0.74 log units) below it; measured number outside the range, above it.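

In this assay, the new chloro group, on an aromatic carbon between two ring nitrogen atoms, gave a 3.0-fold higher number from compound 3 to compound 4 (0.48 log units; beyond the scatter), a rise in the number that means weaker inhibition of growth on this core. Set beside the same change on the other core, the result shows that the step did not carry over from one core to the other in this small set: the same change on two cores in this assay, a 1.8-fold lower number (0.26 log units; within the scatter) from compound 2 to compound 1 and a 3.0-fold higher number (0.48 log units; beyond the scatter) from compound 3 to compound 4, 5.5-fold (0.74 log units) apart, beyond the scatter of two such steps. Among these compounds, it does not show why the two cores part ways, and with only one pair of compounds on each core it cannot establish a rule for the series, while the earlier step, being within the scatter, shows no clear change on its own core, so the firm finding is the gap between the two steps and not a reversal of a proven gain.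

The compounds shown leave open whether a different group at the same ring carbon, such as an amine or a methoxy group, would also behave differently on the two cores. They also leave open whether a third core would follow compound 1 and compound 2, follow compound 3 and compound 4, or do neither.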